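The source may report more compounds than this note shows. Statements on the series, on what has been measured and on what is new or still open speak of the compounds shown alone.

Three related compounds share a core and were tested in a functional assay on KB cells (Homo sapiens) for antiproliferative activity, read by MTT assay, with a stated time of 48 h; a higher number here means a weaker inhibitor, a lower number a stronger inhibitor. Compound 1 `Cn1cc(C2=C(c3nn(CCCn4ccnc4)c4ncccc34)C(=O)N(c3ccccc3)C2=O)c2ccccc21` gives 6800 nM. Compound 2 `COc1ccc(N2C(=O)C(c3cn(C)c4ccccc34)=C(c3nn(CCCN4CCCCC4)c4ncccc34)C2=O)cc1` gives 44000 nM. Compound 3 `Cn1cc(C2=C(c3nn(CCCN4CCCCC4)c4ncccc34)C(=O)NC2=O)c2ccccc21` gives 98000 nM, the highest of the three numbers; its nearest neighbour is compound 2, and compound 1 lies furthest from it.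

Compound 4 `Cn1cc(C2=C(c3nn(CCCN4CCCCC4)c4ncccc34)C(=O)N(c3ccccc3)C2=O)c2ccccc21` has not yet been measured. It differs from compound 3 in one place: phenyl in place of hydrogen on an amide-type nitrogen in a ring. For the measured compounds named here, the one measured step that bears on this change runs the other way, stripping an aryl group from the same nitrogen: a 2.2-fold higher number from compound 2 to compound 3 (0.35 log units; beyond the scatter). Putting an aryl group back is therefore expected to lower the number by a modest amount. Compound 1, which also carries a phenyl on that nitrogen, shows a lower number still, but it differs from compound 4 in another place as well, so only its value is noted.

Compound 4 is expected to give 25000 nM in this assay, with a likely range from 8000 nM to 70000 nM. This estimate means a step of a 3.9-fold lower number from compound 3 to compound 4 (0.59 log units; beyond the scatter).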

Compound 4, half-maximal inhibitory concentration: 5600 nM
Compound 4: the middle estimate sits 4.5-fold (0.65 log units) above what was measured, outside the stated range (below it).
By their numbers in this assay, from the lowest: compounds 4 and 1 (each within the scatter of the next); then compound 2; then compound 3.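

On the amide-type nitrogen of the five-membered ring, a plain phenyl counts for far more than the earlier aryl step suggested: in this assay replacing the hydrogen gives an 18-fold lower number from compound 3 to compound 4 (1.24 log units; beyond the scatter) in this series. The methoxy on that aryl ring also matters, since removing it from the 4-methoxyphenyl group gives a 7.9-fold lower number from compound 2 to compound 4 (0.90 log units; beyond the scatter) at this same position. With phenyl on the nitrogen, the piperidin-1-yl and 1H-imidazol-1-yl groups at the end of the chain cannot be told apart, with a 1.2-fold lower number from compound 1 to compound 4 (0.08 log units; within the scatter) as the step between them.

Still open, from the compounds shown here alone, is whether a methyl, a benzyl or a fluorine on the phenyl ring would keep this gain on the nitrogen. Nothing available explains the size of these steps.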